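This account rests on a few compounds, and the source may have more. Where it says the series, first, only, none or still open, it means among the compounds named here.

Compound 1, `COc1ccc(NC(=O)Nc2cc(C)nc3ccccc23)cc1`, gives > 25000 nM in an ADME assay on HepG2 cells (Homo sapiens) for cytotoxicity, with a stated time of 72 h (a lower number here means that less compound is needed, a higher number that more compound is needed for the effect), which is a limit of the assay rather than a number. Compound 2, `Cc1cc(NC(=O)Nc2ccc(C(=O)O)cc2)c2ccccc2n1`, gives > 25000 nM in this assay, again a limit. Compound 3, `Cc1cc(NC(=O)Nc2ccc(C(N)=O)cc2)c2ccccc2n1`, gives > 25000 nM in this assay, also a limit.

Compound 3 therefore stands at the limit of > 25000 nM in this assay, at which 3 of the 3 values shown sit, and where it lies relative to the other two cannot be read. The steps a step that the two limits leave unreadable from compound 1 to compound 2, a step that the two limits leave unreadable from compound 1 to compound 3 and a step that the two limits leave unreadable from compound 2 to compound 3 are unreadable for the same reason, so none of them offers a size to lean on. Compound 4, `Cc1cc(NC(=O)Nc2ccc(C(C)(C)C)cc2)c2ccccc2n1`, differs from compound 3 by tert-butyl in place of carbamoyl on an aromatic carbon. Within the data shown here, no measured step involves a tert-butyl group, and the three measured variations at this aromatic carbon all left the reading at the limit, so the expectation for compound 4 is that a number no higher from compound 3 to compound 4 (the limit leaves the size open) stays within the scatter and the reading quite likely remains a limit. The estimate for compound 4 in this assay is 25000 nM, with a range from 8000 nM to 60000 nM.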

Compound 4, half-maximal effective concentration: 17000 nM
Beside the measured number, compound 4's estimate is 1.5-fold (0.17 log units) above it; the range from low to high includes it.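

Among the four compounds, only compound 4, with tert-butyl on this aromatic carbon, gives a number rather than a limit in this assay, while methoxy, carboxy and carbamoyl at the same place all stop at the limit: the limit of > 25000 nM in this assay, at which 3 of the 4 values shown sit. The steps among compounds 1, 2 and 3 cannot be read, but swapping each of those groups for tert-butyl gives an at least 1.4-fold lower number from compound 3 to compound 4 (0.16 log units; that floor lies within the scatter) and an at least 1.4-fold lower number from compound 2 to compound 4 (0.16 log units; that floor lies within the scatter) and an at least 1.4-fold lower number from compound 1 to compound 4 (0.16 log units; that floor lies within the scatter) as readable floors. Among these compounds, each floor lies within the scatter, so this shows only that a reading can be obtained with this change, not how large the change really is.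

The compounds shown leave open whether a smaller alkyl group such as ethyl, a chlorine atom or an amine at this place would also give a number. They also leave open whether tert-butyl would give a number on a different core.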